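The source may report more compounds than this note shows. Statements on the series, on what has been measured and on what is new or still open speak of the compounds shown alone.

Compound 1 `Cc1nc(C(=O)Nc2ccc(Cl)c(-c3nnc4c(Cl)cccn34)c2)cs1` in a functional assay on MCF7 cells (Homo sapiens) for antiproliferative activity, read by MTT assay, with a stated time of 72 h (a higher number here means a weaker inhibitor, a lower number a stronger inhibitor), gives > 100000 nM, which is a limit of the assay and not a number.
Compound 2 `O=C(Nc1ccc(Cl)c(-c2nnc3c(Cl)cccn23)c1)c1ccon1` gives > 100000 nM, likewise a limit of the assay.

Compound 2 therefore stands at the limit, where the limit of > 100000 nM in this assay, at which 2 of the 2 values shown sit, places both measured values. Among the compounds with values here, the single measured change, a step that the two limits leave unreadable from compound 1 to compound 2, gives no readable size. Compound 3 `O=C(Nc1ccc(Cl)c(-c2nnc3c(Cl)cccn23)c1)c1ccccc1Cl` differs from compound 2 by 2-chlorophenyl in place of 1,2-oxazol-3-yl on a carbonyl carbon. Within the data shown here, no measured step bears on this change, so neither a direction nor a size beyond the scatter can be drawn from the data. Compound 3 is expected to remain near the limit, estimated at 100000 nM, with a range of 20000 nM to 300000 nM. The step of a number no higher from compound 2 to compound 3 (the limit leaves the size open) is expected to be none beyond the scatter.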

Compound 3, half-maximal inhibitory concentration: 92200 nM
Compound 3: the middle estimate sits 1.1-fold (0.04 log units) above what was measured; measured number inside the range.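

Within the data shown here, putting 2-chlorophenyl on this carbonyl carbon gives the first value in the set that is a number and not a limit. Both steps still give only a floor: an at least 1.0-fold lower number from compound 2 to compound 3 (0.03 log units; that floor lies within the scatter), and an at least 1.0-fold lower number from compound 1 to compound 3 (0.03 log units; that floor lies within the scatter). An all-carbon aromatic ring at this place is therefore not shown to differ beyond the scatter from either five-membered ring, and the set stays close to one ceiling: the limit of > 100000 nM in this assay, at which 2 of the 3 values shown sit.

Whether the chlorine matters is open, and a plain phenyl would test that. Also open, as far as these compounds go, is whether an amine or a carboxylic acid on this ring would bring the number far lower.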